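The source may hold more compounds than are shown below. What is called first, only, known or untested is meant among the compounds shown, and "the series" means these compounds.

Compound 1 `Cc1cc(C)n(-c2ccc(Cl)c(C(=O)NC(=O)Nc3nc4ccc(S(=O)(=O)CCCN5CCN(C)CC5)cc4s3)c2)n1` and compound 2 `CN1CCN(CCCS(=O)(=O)c2ccc3nc(NC(=O)NC(=O)c4cc(-n5cccn5)c(Cl)cc4Cl)sc3c2)CC1` share a core and have both been measured in an assay on HEK293 cells for displacement of a labelled ligand from growth hormone secretagogue receptor type 1 (Homo sapiens), with a stated time of 60 min; a lower number here means a stronger inhibitor, a higher number a weaker inhibitor. Compound 1 gives 1.3 nM in this assay, the higher of the two numbers. Compound 2 gives 0.31 nM, a lower number by a margin beyond the usual scatter; compound 2 differs from compound 1 in more than one place, so no single change accounts for that gap. Compound 3 `Cc1ccn(-c2ccc(Cl)c(C(=O)NC(=O)Nc3nc4ccc(S(=O)(=O)CCCN5CCN(C)CC5)cc4s3)c2)n1` differs from compound 1 by hydrogen in place of methyl on an aromatic carbon. In this assay a step of a 1.2-fold higher number from compound 1 to compound 3 (0.06 log units; within the scatter) is expected, not beyond the scatter. For compound 3 the expected value is 1.5 nM, range 0.5 nM to 4.5 nM.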

Compound 3, half-maximal inhibitory concentration: 0.53 nM
The estimate for compound 3 lay 2.8-fold (0.45 log units) above the measured number; measured number inside the range.
By their numbers in this assay, from the lowest: compounds 2 and 3 (each within the scatter of the next); then compound 1.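

Removing this methyl does not cost binding: in this assay the change from 3,5-dimethyl-1H-pyrazol-1-yl to 3-methyl-1H-pyrazol-1-yl gives a 2.5-fold lower number from compound 1 to compound 3 (0.39 log units; beyond the scatter). This first single-place step in the series shows that the aromatic carbon next to the ring atom that bears a large group needs no methyl for a low number, and that hydrogen there does better, though modestly. Nothing available explains the step.

Still open, going by these compounds, is how an ethyl, methoxy or chlorine at this carbon would read. On these data alone, the effect of replacing the remaining methyl with hydrogen is also open.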